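A Mirror-Image Pair Tested for Cell Toxicity

This account rests on a few compounds, and the source may have more. Where it says the series, first, only, none or still open, it means among the compounds named here.

Among the compounds with values here, compound 3 `O=c1nc(N2CC[C@](O)(COc3ccc(F)cc3)[C@@H](O)C2)sc2c([N+](=O)[O-])cc(C(F)(F)F)cc12` is the only member of this set with a number rather than a limit: in a toxicity assay on HeLa cells (Homo sapiens) for cytotoxicity, read by colorimetric assay, with a stated time of 72 h (a higher number here means that more compound is tolerated, a lower number that less compound is tolerated), compound 3 gives 34300 nM. Compound 1 `O=c1nc(N2CCC(Oc3ccc(OC(F)(F)F)cc3)CC2)sc2c([N+](=O)[O-])cc(C(F)(F)F)cc12` reaches only the limit of this assay, at > 93000 nM. Compound 2 `O=c1nc(N2CC[C@@H](c3ccccc3)[C@H](O)C2)sc2c([N+](=O)[O-])cc(C(F)(F)F)cc12` likewise stops at the limit, at > 93000 nM. Compound 4 `O=c1nc(N2CC[C@@](O)(COc3ccc(F)cc3)[C@H](O)C2)sc2c([N+](=O)[O-])cc(C(F)(F)F)cc12` is the mirror image of compound 3: the two compounds have the same atoms and bonds and differ only in configuration as drawn: 2 of 2 stereo elements differ (all stereocentres are inverted: mirror images); a stereocentre at a saturated ring carbon is drawn S in compound 3 and R in compound 4; a stereocentre at a saturated ring carbon is drawn S in compound 3 and R in compound 4. Within the data shown here, no measured pair in this set differs by a single change, so the effect of inverting configuration is untested here; such a swap is expected to shift the tolerated amount little, if at all, beyond the usual scatter. Compound 4 is therefore estimated at 45000 nM, between 20000 nM and 93000 nM, an expected step of a 1.3-fold higher number from compound 3 to compound 4 (0.12 log units; within the scatter).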

Compound 4, half-maximal cytotoxic concentration: 18400 nM
Compound 4: the middle estimate sits 2.4-fold (0.39 log units) above what was measured; measured number outside the range, below it.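

Within the data shown here, compounds 3 and 4 give the first direct look at configuration in this set. Inverting both ring stereocentres produces only a small step in this assay (a 1.9-fold lower number from compound 3 to compound 4 (0.27 log units; within the scatter)), so this assay does not separate the two mirror images. No other structural change can contribute to this comparison: the fact that compounds 3 and 4 differ only in the configuration as drawn.

Going by these compounds, whether an amine or a carboxylic acid in place of the fluorinated aromatic ether would change the tolerated amount remains open. Compounds 1 and 2 cannot settle this or be ranked against each other: the limit of > 93000 nM in this assay, at which 2 of the 4 values shown sit.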